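This account rests on a few compounds, and the source may have more. Where it says the series, first, only, none or still open, it means among the compounds named here.

In a functional assay on HT-22 cells (Mus musculus) for cytotoxicity (a higher number here means that more compound is tolerated, a lower number that less compound is tolerated), compound 1, `CCOc1c(C)cc2c(c1C)C=CC(C)(C)N2`, gives 182 uM. Compound 2, `CCOc1c(C)c(C)c2c(c1C)C=CC(C)(C)N2`, differs from compound 1 in a single place, (methyl in place of hydrogen on an aromatic carbon), and in this assay compound 2 gives 123 uM. The size of that change is told by the step of a 1.5-fold lower number from compound 1 to compound 2 (0.17 log units; within the scatter). Compound 3, `CCOc1c(C)cc2c(c1C)CCC(C)(C)N2`, is built on a different core; the difference between the two cores is not broken down here. In this assay compound 3 gives 186 uM. Compound 4, `CCOc1c(C)c(C)c2c(c1C)CCC(C)(C)N2`, has not been measured yet; it differs from compound 3 by methyl in place of hydrogen on an aromatic carbon. For the measured compounds named here, the surroundings of the entering methyl read the same in both cases, so this is the same change as the one from compound 1 to compound 2, now made on the core of compound 3. Because the earlier step of a 1.5-fold lower number from compound 1 to compound 2 (0.17 log units; within the scatter) stayed small, a similar step is expected in this assay, namely a 1.5-fold lower number from compound 3 to compound 4 (0.17 log units; within the scatter). Compound 4 is therefore estimated to give 125 uM in this assay, most likely between 80 uM and 200 uM.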

Compound 4, half-maximal toxic concentration: 128 uM
Compound 4: the middle estimate sits 1.0-fold (0.01 log units) below what was measured; low and high end bracket the measured number.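

In this assay, methyl in place of hydrogen on the aromatic carbon gives a 1.5-fold lower number from compound 3 to compound 4 (0.16 log units; within the scatter). Set beside the earlier step, the same change reads alike on both cores: the same change on two cores in this assay, a 1.5-fold lower number (0.17 log units; within the scatter) from compound 1 to compound 2 and a 1.5-fold lower number (0.16 log units; within the scatter) from compound 3 to compound 4, 1.0-fold (0.01 log units) apart, within the scatter of two such steps. For the compounds shown here, this agreement does not show that the methyl has a real effect in this assay, since each step on its own lies within the scatter, and it covers only two cores and one assay, so it says only that no difference between the cores can be seen here.

The compounds shown leave open whether a different group on this aromatic carbon, such as an ethyl chain, a chlorine atom, a methoxy group or an amine, would give a step beyond the scatter, and whether such a step would then carry from one core to the other as closely. They also leave open what happens when the ethoxy group is replaced, for example by a hydroxyl group or a longer chain.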